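The source may report more compounds than this note shows. Statements on the series, on what has been measured and on what is new or still open speak of the compounds shown alone.

Compound 1 `CC1(C)CC(C)(C)c2cc(NC(=O)Nc3ccc([N+](=O)[O-])cc3)ccc2O1` and compound 2 `CC1(C)CC(C)(C)c2cc(NC(=O)Nc3ccc(C(F)(F)F)cc3)ccc2O1` share one core, while compound 3 `CCC1(CC)CC(C)(C)Oc2ccc(NC(=S)Nc3ccc([N+](=O)[O-])cc3)cc21` and the not yet measured compound 4 `CCC1(CC)CC(C)(C)Oc2ccc(NC(=S)Nc3ccc(C(F)(F)F)cc3)cc21` share another; the difference between the two cores is not broken down here. In a functional assay on A2780 cells (Homo sapiens) for inhibition, with a stated time of 72 h, tested at 10 uM (on this read-out lower numbers stand for less inhibition of growth and higher numbers for more inhibition of growth at the one concentration tested), compound 1 gives 79% and compound 2 gives 88.4%. In this assay compound 3 gives 95.7%, a number that lies beyond the usual scatter from the value of compound 1 but within it of the value of compound 2.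

Compound 2 differs from compound 1 in one place, (trifluoromethyl in place of nitro on an aromatic carbon), and this change made a step of a number 9.4 percentage points higher from compound 1 to compound 2 (within the scatter). Compound 4 differs from compound 3 by the same change at the same place, (trifluoromethyl in place of nitro on an aromatic carbon). Among the four compounds this change occurs twice, and the measured pair is the only guide to what it does in this assay.

The earlier step was small, and compound 3 already stands close to the top of what this read-out can report, so the same change is expected to add little; the step from compound 3 to compound 4 is estimated at a number 1.3 percentage points higher from compound 3 to compound 4 (within the scatter). Compound 4 is therefore expected to give about 97% in this assay, with the likely range running from 90% to 100%, the upper end being bounded by the ceiling of the read-out itself.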

Compound 4, percent growth inhibition at one concentration: 11.8%
Compound 4: the middle estimate sits 85.2 percentage points above what was measured; measured number below the stated range.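

In this assay, the replacement of nitro by trifluoromethyl on the core of compound 3 gave a number 83.9 percentage points lower from compound 3 to compound 4 (beyond the scatter), whereas the same replacement on the core of compound 1 gave a step that stayed within the usual scatter. For the compounds shown here, the effect of this change therefore did not carry from one core to the other, and the two measured pairs differ clearly: the same change on two cores in this assay, a number 9.4 percentage points higher (within the scatter) from compound 1 to compound 2 and a number 83.9 percentage points lower (beyond the scatter) from compound 3 to compound 4, 93.3 percentage points apart, beyond the scatter of two such steps This shows that a step read on one of these cores is no safe guide to the other, but it does not show which feature of the two cores is responsible, why growth inhibition fell so sharply, or whether the same divergence would hold at another concentration, since there are only two pairs, each read at the one concentration tested.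

The compounds shown leave open which part of the difference between the two cores decides the outcome, as no compound here separates those differences one at a time. They also leave open how other groups in the place of nitro, such as a chlorine atom, a methoxy group or an amine, would behave on each core.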